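Pyrazole regioisomers in the cyclic urea amide series

The source may report more compounds than this note shows. Statements on the series, on what has been measured and on what is new or still open speak of the compounds shown alone.

Measured so far:
compound 1 `CNC(=O)N1CCCc2ccc(NC(=O)c3ccc(-c4ccccc4)cc3)cc21`: 74.3%
compound 2 `CNC(=O)N1CCCc2ccc(NC(=O)c3cccc(-c4ccn(C)n4)c3)cc21`: 99.5%

In a functional assay on MV4-11 cells (Homo sapiens) for antiproliferative activity, with a stated time of 6 days, tested at 6.25 uM (on this read-out higher numbers stand for a stronger effect at the one concentration tested and lower numbers for a weaker effect), compound 2 gives 99.5%, the highest of the two numbers; compound 1 gives 74.3%, a number lower by more than the usual scatter. For the measured compounds named here, no step between measured compounds is available. Compound 3 `CNC(=O)N1CCCc2ccc(NC(=O)c3cccc(-c4cnn(C)c4)c3)cc21` differs from compound 2 in one place: 1-methyl-1H-pyrazol-4-yl in place of 1-methyl-1H-pyrazol-3-yl on an aromatic carbon. Going by the values given here, no measured step covers this change. The step of a number 6.5 percentage points lower from compound 2 to compound 3 (within the scatter) is expected to be none beyond the scatter. For compound 3 the estimate is 93%, within a range of 78% to 100%.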

Compound 3, a percentage reported as inhibition, at one concentration (the size of the read-out at that concentration, not a potency): 93.5%
Estimate against measurement, compound 3: 0.5 percentage points below; the range from low to high includes it.
By their numbers in this assay, from the lowest: compound 1; then compounds 3 and 2 (each within the scatter of the next).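

In this assay, exchanging 1-methyl-1H-pyrazol-3-yl for 1-methyl-1H-pyrazol-4-yl on this aromatic carbon gives a number 6 percentage points lower from compound 2 to compound 3 (within the scatter), so the two regioisomers cannot be told apart at this place. The read-out at one concentration therefore shows that the point of attachment of the pyrazole can change with no effect beyond the scatter. Nothing available bears on why the two isomers read alike.

From the compounds shown here alone, whether a pyridine or a morpholine at the same place would read alike remains open. Also open, going by these compounds, is whether the two isomers would separate at lower concentrations.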